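The source may hold more compounds than are shown below. What is called first, only, known or untested is meant among the compounds shown, and "the series" means these compounds.

Measured compounds:
Compound 1, `CNC(=O)c1cc(C(=O)NC2CC2)cn(CC2CCCOC2)c1=O`, gives 2 in a physicochemical assay for lipophilicity, at pH 7.4; on this read-out lower numbers stand for lower lipophilicity and higher numbers for higher lipophilicity.
Compound 2, `CNC(=O)c1cc(C(=O)NC2CC2)cn(Cc2ccc3nc[nH]c3c2)c1=O`, gives 1.2 in this assay.
Compound 3, `CNC(=O)c1cc(C(=O)NC2CC2)cn(Cc2nccc3[nH]ccc23)c1=O`, gives 1.7 in this assay.

Compound 3 stands second highest of the three numbers. Its nearest neighbour is compound 1, and the step of a number 0.30 log units lower from compound 1 to compound 3 (within the scatter) is within the scatter, so no order can be read between these two. Its furthest neighbour is compound 2, with a number 0.50 log units higher from compound 2 to compound 3 (beyond the scatter), a modest step beyond the scatter.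

The next compound is compound 4, `CNC(=O)c1cc(C(=O)NC2CC2)cn(Cc2ccc(C)cc2)c1=O`. It differs from compound 3 by a group of 7 heavy atoms (7 carbon; one six-membered aromatic ring of carbon only) in place of a group of 9 heavy atoms (7 carbon, 2 nitrogen; one five-membered aromatic ring with 1 hetero atom, one six-membered aromatic ring with 1 hetero atom), on a saturated chain carbon bound to an aromatic nitrogen.

Within the data shown here, no measured step introduces a plain carbocyclic aryl group at this position, so the bearing of the known steps is indirect. The steps of a number 0.80 log units lower from compound 1 to compound 2 (beyond the scatter) and a number 0.50 log units higher from compound 2 to compound 3 (beyond the scatter) show that exchanging one ring system for another at this saturated chain carbon shifts the read-out by modest amounts beyond the scatter, and that the group with two nitrogen atoms in its five-membered ring sits lowest. Removing both nitrogens and the hydrogen-bond donor and acceptor while adding a methyl is expected to move the number upward by a modest to sizeable step, giving an expected a number 1.00 log units higher from compound 3 to compound 4 (beyond the scatter) in this assay.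

Compound 4 is therefore estimated at 2.7, with a range from 2.2 to 3.2.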

Compound 4, distribution coefficient: 3.5
Compound 4: middle estimate off by 0.80 log units, on the low side; the measured number lies above the stated range.
By their numbers in this assay, from the lowest: compound 2; then compounds 3 and 1 (each within the scatter of the next); then compound 4.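

In this assay, 4-methylphenyl gives the highest number of the four, and all three steps to it are large: (a number 1.80 log units higher from compound 3 to compound 4 (beyond the scatter)), (a number 2.30 log units higher from compound 2 to compound 4 (beyond the scatter)) and (a number 1.50 log units higher from compound 1 to compound 4 (beyond the scatter)). The earlier exchanges on this saturated chain carbon bound to an aromatic nitrogen gave only modest steps or stayed within the scatter, so this position can carry a much wider span of numbers than they showed, and an aromatic ring as such does not place a compound high, since compound 2 and compound 3, both with aromatic ring systems, do not stand above compound 1 with its oxan-3-yl group. Nothing given here explains why the number rises so far with this change.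

The compounds shown leave open how much of the rise belongs to the methyl and how much to the all-carbon ring, and where a plain phenyl group, or a phenyl group carrying an amine or a carboxylic acid, would fall on this scale. They also leave open whether steps of this size would hold if the cyclopropyl amide of the shared core were exchanged for a longer chain.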